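The compounds below may be only part of what the source reports. "The series", "measured", "known", "first", "only" and "open" are said of these compounds alone.

For the measured compounds named here, in a functional assay on U-87MG ATCC cells (Homo sapiens) for cytotoxicity, read by MTT assay, with a stated time of 48 h (a lower number here means a stronger inhibitor, a higher number a weaker inhibitor), two compounds have numbers so far. Compound 1 (`C/C(=N/NC(=S)Nc1ccccc1F)c1ccccn1`) gives 5 nM as its reading, and compound 2 (`C/C(=N/NC(=S)Nc1ccccc1)c1ccccn1`) gives 1.4 nM as its reading, the lower of the two. Compound 3 (`C/C(=N/NC(=S)Nc1ccc(F)cc1)c1ccccn1`) is still unmeasured in this assay and differs from compound 2 as follows (fluoro in place of hydrogen on an aromatic carbon): fluoro in place of hydrogen on an aromatic carbon, para to a large group. Going by the values given here, one measured step bears on this (a 3.6-fold lower number from compound 1 to compound 2 (0.55 log units; beyond the scatter)). Among the compounds with values here, it is modest and beyond the scatter, and it runs the other way, with hydrogen replacing fluoro at a different place from the one in compound 3, so it is only a loose guide. A rise in the number is therefore expected, smaller than that step and possibly none beyond the scatter. The expected step is small (a 1.8-fold higher number from compound 2 to compound 3 (0.25 log units; within the scatter)). For compound 3 the estimated value is 2.5 nM within an expected range of 0.8 nM to 8 nM in this assay.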

Compound 3, half-maximal inhibitory concentration: 10 nM
Estimate against measurement, compound 3: 4.0-fold (0.60 log units) below; the whole stated range lies below it.
By their numbers in this assay, from the lowest: compound 2; then compounds 1 and 3 (each within the scatter of the next).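

In this assay, fluoro in place of hydrogen on an aromatic carbon, para to a large group, is not a neutral change: the record shows a 7.1-fold higher number from compound 2 to compound 3 (0.85 log units; beyond the scatter). Read with a 3.6-fold lower number from compound 1 to compound 2 (0.55 log units; beyond the scatter), where hydrogen replaces fluoro at a different place on the same ring, this shows that the number is lower with hydrogen than with fluoro at both places shown, so the rise is not confined to a single place. Nothing measured here accounts for why one fluorine atom moves the number in this way.

As far as these compounds go, whether a larger halogen such as chloro or bromo, a methoxy group or an amine at this para place would also raise the number remains open. So does whether any group there could bring the number below that of the unsubstituted compound 2.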